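The source may report more compounds than this note shows. Statements on the series, on what has been measured and on what is new or still open speak of the compounds shown alone.

Going by the values given here, compound 2 `Nc1nc(N/N=C/c2ccc3ncccc3c2)nc2c1ncn2[C@@H]1O[C@H](CO)[C@@H](O)[C@H]1O` is the weaker of the two measured members in an assay on CHO-K1 cells for displacement of a labelled ligand from adenosine receptor A1 (Homo sapiens), read by scintillation counting, with a stated time of 60 min (a lower number here means a stronger inhibitor, a higher number a weaker inhibitor), where compound 2 gives 9.8 nM. Among the compounds with values here, its neighbour compound 1 `CCCCC/C=C/C=C/C=N/Nc1nc(N)c2ncn([C@@H]3O[C@H](CO)[C@@H](O)[C@H]3O)c2n1` gives 2 nM in this assay, and the single step recorded, a 4.9-fold higher number from compound 1 to compound 2 (0.69 log units; beyond the scatter), separates them. Compound 3 `CSCC/C=N/Nc1nc(N)c2ncn([C@@H]3O[C@H](CO)[C@@H](O)[C@H]3O)c2n1` carries a further change on the same carbon: 2-(methylsulfanyl)ethyl in place of quinolin-6-yl on a carbon with a double bond to nitrogen. Within the data shown here, the only step that bears on this place is the one from compound 1 to compound 2, which exchanged a long open chain for a fused aromatic pair and cost a modest amount of binding; compound 3 instead removes the aromatic pair and leaves a much shorter chain, so no measured step matches it directly. A further weakening is the expected direction, and compound 3 is estimated at 30 nM in this assay, within 6 nM to 150 nM, meaning a step of a 3.1-fold higher number from compound 2 to compound 3 (0.49 log units; beyond the scatter).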

Compound 3, inhibition constant: > 10000 nM
Compound 3 ended at the assay's limit; the forecaster's own chance of this, stated with the estimate: 5%; middle value at least 330-fold (2.52 log units) away from the limit.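

Compound 3 stands at a limit of the assay, so its value is a limit and not a number: the limit of > 10000 nM in this assay, at which 1 of the 3 values shown sits. The step from the open chain to quinolin-6-yl had been modest, but this change at the same place is large (an at least 1000-fold higher number from compound 2 to compound 3 (3.00 log units; beyond the scatter)), and it is large again against the long chain of compound 1 (an at least 5000-fold higher number from compound 1 to compound 3 (3.69 log units; beyond the scatter)). In this assay, binding at this carbon with a double bond to nitrogen therefore holds with either a long open chain or a fused aromatic pair, and it is lost with 2-(methylsulfanyl)ethyl, so the position tolerates different groups but not every group.

The compounds shown do not separate the shortness of this chain from the sulfur it carries. A short chain of carbon only, or a longer chain ending in the same methylsulfanyl group, would tell these two apart.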